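Adding a Methoxy Group: Expectations for Compound 4

The source may report more compounds than this note shows. Statements on the series, on what has been measured and on what is new or still open speak of the compounds shown alone.

Measured so far:
compound 1 `Cc1ccc2cccc(NS(=O)(=O)c3ccccc3[N+](=O)[O-])c2n1` gives 3800 nM
compound 2 `O=[N+]([O-])c1cc(C(F)(F)F)ccc1S(=O)(=O)Nc1cccc2cccnc12` gives 3700 nM
compound 3 `COc1cc(NS(=O)(=O)c2ccc(C)cc2[N+](=O)[O-])c2ncccc2c1` gives 2100 nM

All three compounds share one core and were tested in an assay on isolated protein (HUVEC cells) for inhibition of transcription factor p65 (Homo sapiens); a lower number here means a stronger inhibitor, a higher number a weaker inhibitor. Compound 1 stands with its value beside compound 2, whose number differs from it by less than the usual scatter, and compound 3, whose number also lies within that scatter of compound 1; on these figures the three cannot be told apart.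

Compound 4 `COc1ccc(S(=O)(=O)Nc2cccc3ccc(C)nc23)c([N+](=O)[O-])c1` has not yet been measured. Compared with compound 1, the difference is methoxy in place of hydrogen on an aromatic carbon of a six-membered aromatic ring of carbon only, meta to a nitro group and para to a large group. For the measured compounds named here, no pair of measured compounds shows what this change does, so there is nothing to build a direction on. The expected outcome is therefore a step no larger than the scatter, in either direction, from compound 1 to compound 4 of about a 1.3-fold lower number from compound 1 to compound 4 (0.10 log units; within the scatter) in this assay. For compound 4 the estimate in this assay is 3000 nM, within a range from 1000 nM to 9000 nM.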

Compound 4, half-maximal inhibitory concentration: 1000 nM
For compound 4 the middle estimate is 3.0-fold (0.48 log units) above the measured one; the range from low to high includes it.
By their numbers in this assay, from the lowest: compound 4; then compounds 3, 2 and 1 (each within the scatter of the next).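

Methoxy in place of hydrogen on an aromatic carbon, meta to a nitro group and para to a large group, brings a 3.8-fold lower number from compound 1 to compound 4 (0.58 log units; beyond the scatter) in this assay and so marks this position as one where a single small change can move the number past the scatter. The earlier compounds shown here could not show this: their numbers lay within the scatter of compound 1, and no two of them differed in one place only. No measurement at hand says why the number drops with this change.

From the compounds shown here alone, a single step at a single position gives no trend, so it stays open whether the drop is particular to methoxy or would also come with a methyl, an ethoxy, an amine or a fluorine at the same place. Going by these compounds, it also stays open whether methoxy would give a similar step on other compounds that carry the shared core.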